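A few compounds are considered here, and "the series" means these few. Any claim that something is new, unique, unknown or untested is made for them only; others in the source may bear on it.

Compound 1 `O=C(CSCc1nc2cc([N+](=O)[O-])ccc2[nH]1)c1ccccc1` gives 16100 nM in a functional assay on HepG2 cells (Homo sapiens) for cytotoxicity, read by MTT assay, with a stated time of 48 h; a higher number here means a weaker inhibitor, a lower number a stronger inhibitor. Compound 3 `N#CCSCc1nc2cc([N+](=O)[O-])ccc2[nH]1` gives 30600 nM. Compound 2 `CCOC(=O)CSCc1nc2cc([N+](=O)[O-])ccc2[nH]1` reaches only a limit of the assay, > 100000 nM, not a number (the limit of > 100000 nM in this assay, at which 1 of the 3 values shown sits). Of the two numbers, compound 3 has the higher one, though its gap to compound 1 lies within the scatter. Compound 4 `NC(=O)CSCc1nc2cc([N+](=O)[O-])ccc2[nH]1` differs from compound 3 by carbamoyl in place of cyano on a saturated chain carbon bound to a sulfur. Within the data shown here, two measured steps bear on this position: an at least 6.2-fold higher number from compound 1 to compound 2 (0.79 log units; beyond the scatter) and an at least 3.2-fold lower number from compound 2 to compound 3 (0.51 log units; beyond the scatter), each at least modest and beyond the scatter. Among the measured compounds shown here, the carbamoyl group has no measured precedent here, so a step beyond the scatter in either direction is possible; the expected step is a 1.5-fold higher number from compound 3 to compound 4 (0.17 log units; within the scatter), toward a weaker inhibitor. Compound 4 is therefore estimated at 45000 nM, in the range 15000 nM to 130000 nM.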

Compound 4, half-maximal inhibitory concentration: 26900 nM
The estimate for compound 4 lay 1.7-fold (0.22 log units) above the measured number; low and high end bracket the measured number.
By their numbers in this assay, from the lowest: compounds 1, 4 and 3 (each within the scatter of the next). At a limit, above all of these: compound 2.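

In this assay, carbamoyl in place of cyano on a saturated chain carbon bound to a sulfur gives no change beyond the scatter (a 1.1-fold lower number from compound 3 to compound 4 (0.06 log units; within the scatter)), and the step on a carbonyl carbon also stays within it (a 1.7-fold higher number from compound 1 to compound 4 (0.22 log units; within the scatter)). Only ethoxy on that carbonyl carbon stands apart from amino (an at least 3.7-fold lower number from compound 2 to compound 4 (0.57 log units; beyond the scatter)). The value for compound 2 is a limit and not a number: the limit of > 100000 nM in this assay, at which 1 of the 4 values shown sits. Going by these compounds, whether a carboxylic acid or a longer chain on a saturated chain carbon bound to a sulfur would move the number beyond the scatter from compound 4 stays open.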